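Ester variation on the shared core: compound 3 to compound 4

The source may report more compounds than this note shows. Statements on the series, on what has been measured and on what is new or still open speak of the compounds shown alone.

Compound 3 `C#CCCOC(=O)c1ccc(C(CC)(CC)c2ccc(OCC(O)C(C)(C)C)c(C)c2)n1CC` gives 1030 nM in an assay on HL-60 cells for agonist activity at vitamin D3 receptor (Homo sapiens), read by microscopy, with a stated time of 96 h (on this read-out higher numbers stand for an effect only at larger amounts of compound and lower numbers for an effect already at smaller amounts), and stands second highest of the three measured numbers: compound 1 `C=CCN(C)C(=O)c1ccc(C(CC)(CC)c2ccc(OCC(O)C(C)(C)C)c(C)c2)n1CC` gives 3950 nM and compound 2 `CCn1c(C(=O)N(CCC#N)CCC#N)ccc1C(CC)(CC)c1ccc(OCC(O)C(C)(C)C)c(C)c1` gives 97 nM. Compound 4 `CCn1c(C(=O)Oc2ccc(CCO)cc2)ccc1C(CC)(CC)c1ccc(OCC(O)C(C)(C)C)c(C)c1` differs from compound 3 by 4-(2-hydroxyethyl)phenyl in place of but-3-yn-1-yl on an oxygen next to a carbonyl group. Going by the values given here, no measured step changes this oxygen-bound group directly; the three known steps all alter the group on the carbonyl carbon, with a 3.8-fold lower number from compound 1 to compound 3 (0.58 log units; beyond the scatter), a 41-fold lower number from compound 1 to compound 2 (1.61 log units; beyond the scatter) and an 11-fold higher number from compound 2 to compound 3 (1.03 log units; beyond the scatter). Changes at this end of the shared core therefore range from modest to large, and the lowest number belongs to compound 2, which carries the largest group there. For compound 4 a modest lowering is expected, a 2.1-fold lower number from compound 3 to compound 4 (0.31 log units; beyond the scatter), with wide uncertainty. Compound 4 is estimated at 500 nM, between 120 nM and 2500 nM.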

Compound 4, half-maximal effective concentration: 5100 nM
Compound 4: middle estimate off by 10-fold (1.01 log units), on the low side; measured number above the stated range.
By their numbers in this assay, from the lowest: compound 2; then compound 3; then compounds 1 and 4 (each within the scatter of the next).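

In this assay, the group on an oxygen next to a carbonyl group responds to change: 4-(2-hydroxyethyl)phenyl in place of but-3-yn-1-yl gives a 5.0-fold higher number from compound 3 to compound 4 (0.69 log units; beyond the scatter), the opposite direction to the step from compound 1 to compound 2 towards a larger group. Compound 4 carries the largest group on the carbonyl carbon, yet the series shows a 53-fold higher number from compound 2 to compound 4 (1.72 log units; beyond the scatter) and a 1.3-fold higher number from compound 1 to compound 4 (0.11 log units; within the scatter), so group size alone does not track the number here. The data give no reason for these steps. Open, as far as these compounds go, is whether the aromatic ring or the hydroxyethyl chain accounts for the step from compound 3, and how a plain phenyl or a longer alkyl chain on this oxygen would read.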